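The source may report more compounds than this note shows. Statements on the series, on what has been measured and on what is new or still open speak of the compounds shown alone.

Measured compounds:
Compound 1 `O=[N+]([O-])c1cncn1CCS(=O)(=O)NCCO`; in a physicochemical assay for solubility, read by HPLC (on this read-out higher numbers stand for higher solubility and lower numbers for lower solubility), compound 1 gives 69300000 nM.
Compound 2 `O=[N+]([O-])c1cn(CCS(=O)(=O)NCCO)cn1`; in this assay compound 2 gives only a limit, > 100000000 nM.
Compound 3 `Cc1ncc([N+](=O)[O-])n1CCS(=O)(=O)NCCO`; in this assay compound 3 gives only a limit, > 49300000 nM.

Compound 3 stands at a limit of this assay rather than at a number (the limit of > 49300000 nM in this assay, at which 1 of the 3 values shown sits). One further value shown, that of compound 2, is also a limit (the limit of > 100000000 nM in this assay, at which 1 of the 3 values shown sits). Among the measured compounds shown here, the only step between measured compounds, a step that the limit leaves unreadable from compound 1 to compound 3, is left unreadable by that limit.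

Compound 4 `Cc1ncc([N+](=O)[O-])n1CCS(=O)(=O)NCCCN(C)C` differs from compound 3 by (dimethylamino)methyl in place of hydroxy on a saturated chain carbon, two bonds along the chain from a sulfonamide nitrogen. None of the measured steps covers this change: the single step shown is unreadable, and no pair among the measured compounds differs at the chain beyond the sulfonamide nitrogen. The expected step that the limit leaves unreadable from compound 3 to compound 4 is therefore no more than the scatter, with a fair chance that the read-out again stops at a limit. Compound 4 is expected to give about 50000000 nM, within 10000000 nM to 100000000 nM.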

Compound 4, solubility: > 53800000 nM
Compound 4 was reported as a limit (the forecaster's own chance of this, stated with the estimate: 55%); middle value at least 1.0-fold (0.03 log units) away from the limit.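

In this assay compound 3 gives only a limit, > 49300000 nM. Compound 4 also gives only a limit, > 53800000 nM. No step can be read between compound 3 and compound 4. The compounds shown leave open the size of any change in solubility with (dimethylamino)methyl in place of hydroxy.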